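This account rests on a few compounds, and the source may have more. Where it says the series, first, only, none or still open, it means among the compounds named here.

Two compounds share the same core. Compound 1 `CC(C)(C)c1ccc(Cc2nc(N)n(CC(=O)Nc3ccccc3)c2-c2ccccc2Br)cc1` gives 4900 nM in a functional assay on MIA PaCa-2 cells (Homo sapiens) for antiproliferative activity, read by MTT assay, with a stated time of 48 h (on this read-out lower numbers stand for stronger inhibition and higher numbers for weaker inhibition), and compound 2 `Cc1ccc(NC(=O)Cn2c(N)nc(CC3CCCC3)c2-c2ccccc2Br)cc1` gives 80500 nM in this assay, the higher of the two numbers; the gap between them lies beyond the scatter. Compound 3 `Cc1ccc(NC(=O)Cn2c(N)nc(Cc3ccc(C(C)(C)C)cc3)c2-c2ccccc2Br)cc1` carries 4-(tert-butyl)phenyl in place of cyclopentyl on a saturated chain carbon bound to an aromatic carbon, so that it bears the same 4-(tert-butyl)benzyl group as compound 1. Because compound 1 gives 4900 nM, the step from compound 2 to compound 3 is expected to be a clear fall, a 13-fold lower number from compound 2 to compound 3 (1.13 log units; beyond the scatter). Compound 3 is therefore expected to give about 6000 nM in this assay, within a range from 2000 nM to 20000 nM.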

Compound 3, half-maximal inhibitory concentration: 3400 nM
Compound 3: middle estimate off by 1.8-fold (0.25 log units), on the high side; the measured number falls inside the stated range.
By their numbers in this assay, from the lowest: compounds 3 and 1 (each within the scatter of the next); then compound 2.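

In this assay, 4-(tert-butyl)phenyl in place of cyclopentyl on a saturated chain carbon bound to an aromatic carbon gives a 24-fold lower number from compound 2 to compound 3 (1.37 log units; beyond the scatter), so this position strongly influences the read-out. Methyl in place of hydrogen on an aromatic carbon gives a 1.4-fold lower number from compound 1 to compound 3 (0.16 log units; within the scatter), so that methyl makes no clear difference when the 4-(tert-butyl)benzyl group is present. Nothing available explains the large step. From the compounds shown here alone, it remains open whether the aromatic ring or the tert-butyl group accounts for the large step; an unsubstituted benzyl group in this place would help separate the two.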